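Moving the pyridine nitrogen from compound 3 to compound 4

The source may hold more compounds than are shown below. What is called first, only, known or untested is meant among the compounds shown, and "the series" means these compounds.

Measured in an ADME assay on microsomes (Homo sapiens) for metabolic stability; on this read-out lower numbers stand for slow clearance and higher numbers for fast clearance:
compound 1 `CNC(=O)[C@@H]1CCCN1S(=O)(=O)c1ccc(Cl)c(COc2cccc3c(-n4ccnc4)cc(C)nc23)c1Cl` gives 33.3 mL/min/kg here
compound 2 `CNC(=O)[C@@H]1CCCN1S(=O)(=O)c1ccc(Cl)c(COc2cccc3c(-c4cncn4C)cc(C)nc23)c1Cl` gives 33.3 mL/min/kg here
compound 3 `CNC(=O)[C@@H]1CCCN1S(=O)(=O)c1ccc(Cl)c(COc2cccc3c(-c4ccccn4)cc(C)nc23)c1Cl` gives 183 mL/min/kg here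

Compound 3 has the highest number of the three. The steps that bring in its pyridin-2-yl group show a 5.5-fold higher number from compound 1 to compound 3 (0.74 log units; beyond the scatter) and a 5.5-fold higher number from compound 2 to compound 3 (0.74 log units; beyond the scatter) in this read-out. The other pair shows no change at the digits printed from compound 1 to compound 2 (within the scatter) for its exchange.

Compound 4 `CNC(=O)[C@@H]1CCCN1S(=O)(=O)c1ccc(Cl)c(COc2cccc3c(-c4ccncc4)cc(C)nc23)c1Cl` has the same atoms as compound 3, joined differently: pyridin-4-yl in place of pyridin-2-yl on an aromatic carbon with pyridin-4-yl in place of pyridin-2-yl on an aromatic carbon. Among the compounds with values here, no measured step compares two pyridines, so the size of this step is uncertain. Compound 3 stands alone at the top of a small set, and a modest fall is expected, smaller than the measured rise from compound 2 at 33.3 mL/min/kg to the pyridin-2-yl compound. The expected change is a 2.2-fold lower number from compound 3 to compound 4 (0.33 log units; beyond the scatter) by this estimate. In this assay the estimate for compound 4 is 85 mL/min/kg with 33 mL/min/kg to 190 mL/min/kg as its expected range.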

Compound 4, clearance: 217 mL/min/kg
The estimate for compound 4 lay 2.6-fold (0.41 log units) below the measured number; measured number above the stated range.
By their numbers in this assay, from the lowest: compounds 1 and 2 (each within the scatter of the next); then compounds 3 and 4 (each within the scatter of the next).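

In this assay, the position of the nitrogen within the pyridine matters little at this carbon, opposite the ring nitrogen of the shared core: pyridin-4-yl in place of pyridin-2-yl gives a 1.2-fold higher number from compound 3 to compound 4 (0.07 log units; within the scatter). The high clearance is therefore not peculiar to pyridin-2-yl, as pyridin-4-yl also stands apart from the two imidazole-bearing compounds, with a 6.5-fold higher number from compound 2 to compound 4 (0.81 log units; beyond the scatter) and a 6.5-fold higher number from compound 1 to compound 4 (0.81 log units; beyond the scatter). Nothing available explains why the two pyridines and the two imidazoles separate in this way.

The compounds shown leave open whether pyridin-3-yl would sit with the other two pyridines, and whether a phenyl or pyrimidin-5-yl group at this carbon would fall with the pyridines or with the imidazoles. They also leave open whether the same gap would hold with an ethyl group in place of the methyl group on the shared core.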